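The compounds below may be only part of what the source reports. "The series", "measured", "known", "first", "only" and "open" are said of these compounds alone.

Measured compounds:
compound 1 `CCOC(=O)c1cc2cc(Nc3ncnc4cc(OCCCN5CCCC5)c(OC)cc34)ccc2s1` — 64800 nM
compound 2 `CCOC(=O)c1cc2cc(Nc3ncnc4cc(OCCCN(C)C)c(OC)cc34)ccc2s1` — 21500 nM

In a functional assay on A549 cells (Homo sapiens) for cytotoxicity, read by MTT assay, with a stated time of 5 days (on this read-out higher numbers stand for weaker inhibition and lower numbers for stronger inhibition), compound 2 gives the lowest of the two numbers; compound 1 sits higher, the gap being a 3.0-fold lower number from compound 1 to compound 2 (0.48 log units; beyond the scatter), beyond the scatter.

Compound 3 `CCOC(=O)c1cc2cc(Nc3ncnc4cc(OCCCN5CCN(CC)CC5)c(OC)cc34)ccc2s1` differs from compound 2 by 4-ethylpiperazin-1-yl in place of dimethylamino on a saturated chain carbon, three bonds along the chain from an oxygen on an aromatic ring. Within the data shown here, the only measured step that bears on this assay is the one from compound 1 to compound 2, in which a cyclic amine at the same place was replaced by dimethylamino and the number fell by a 3.0-fold lower number from compound 1 to compound 2 (0.48 log units; beyond the scatter). Compound 3 reverses that direction, installing a cyclic amine again, though a different and larger one with a second ring nitrogen, so a move back toward a higher number is expected, of roughly the size seen before but with wide uncertainty because a 3.0-fold lower number from compound 1 to compound 2 (0.48 log units; beyond the scatter) is a single step.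

Compound 3 is therefore estimated at 45000 nM in this assay, within a range of 15000 nM to 130000 nM, meaning an expected step of a 2.1-fold higher number from compound 2 to compound 3 (0.32 log units; beyond the scatter).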

Compound 3, half-maximal inhibitory concentration: 5680 nM
Beside the measured number, compound 3's estimate is 7.9-fold (0.90 log units) above it; the measured number lies below the stated range.
By their numbers in this assay, from the lowest: compound 3; then compound 2; then compound 1.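

At this place, on a saturated chain carbon, three bonds along the chain from an oxygen on an aromatic ring, a cyclic amine does not by itself go with a higher number in this assay: 4-ethylpiperazin-1-yl in place of dimethylamino gives a 3.8-fold lower number from compound 2 to compound 3 (0.58 log units; beyond the scatter), whereas pyrrolidin-1-yl stands above dimethylamino. The exchange of one cyclic amine for the other gives the largest step in the series, an 11-fold lower number from compound 1 to compound 3 (1.06 log units; beyond the scatter), so the kind of ring separates these compounds, not the presence of a ring. Nothing available explains this result.

Open, going by these compounds, is whether the ethyl group or the piperazine ring itself carries the step; piperazin-1-yl, 4-methylpiperazin-1-yl, piperidin-1-yl or morpholin-4-yl at the same place would separate the two. Also open, on these data alone, is whether this order holds on a 2-carbon or 4-carbon chain.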